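Removing the cyclopropyl methyl in the tetrazolylacetamide series

A few compounds are considered here, and "the series" means these few. Any claim that something is new, unique, unknown or untested is made for them only; others in the source may bear on it.

Measured compounds:
- compound 1 `Cc1cc(NC(=O)Cn2nnc(-c3ccccc3)n2)n(C2CCS(=O)(=O)CC2)n1`: in an assay on HEK293 cells for activation of Kir3.1/Kir3.2 (Homo sapiens), read by thallium flux (a higher number here means that more compound is needed for the effect, a lower number that less compound is needed), compound 1 reports > 10000 nM, which is a limit of the assay and not a number.
- compound 2 `CC1CC1c1cc(NC(=O)Cn2nnc(-c3ccccc3)n2)n(C2CCCCC2)n1`: in this assay compound 2 gives 843 nM.

Within the data shown here, compound 2 holds the only actual number in this assay; the other entry is the limit (the limit of > 10000 nM in this assay, at which 1 of the 2 values shown sits), so no measured step exists to calibrate against. Compound 3 `O=C(Cn1nnc(-c2ccccc2)n1)Nc1cc(C2CC2)nn1C1CCCCC1` is the next entry and differs from compound 2 by hydrogen in place of methyl on a saturated ring carbon. Among the measured compounds shown here, no measured step of this kind is available. The expectation is a step from compound 2 to compound 3 of a 1.8-fold higher number from compound 2 to compound 3 (0.25 log units; within the scatter) in this assay, a modest loss that may still fall within the scatter. Compound 3 is therefore estimated at 1500 nM, with a likely range from 500 nM to 5000 nM.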

Compound 3, half-maximal effective concentration: 271 nM
Beside the measured number, compound 3's estimate is 5.5-fold (0.74 log units) above it, and the stated range ends above it.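

In this assay, among these compounds, the change from 2-methylcyclopropyl to cyclopropyl gives the first measured step, a 3.1-fold lower number from compound 2 to compound 3 (0.49 log units; beyond the scatter). The methyl on this saturated ring carbon is therefore not needed for the effect, and with the rest of the molecule held constant, the plain cyclopropyl is the better of the two groups tested at this position. No measured property among the data shown accounts for this step.

How far the position tolerates other groups remains open, as no value is shown for a tert-butyl or a phenyl in place of the cyclopropyl. Compound 1, at > 10000 nM, is a limit of the assay and not a number, and it differs from compound 3 in more than one place, so the separate contributions of those differences cannot be read.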